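A Smaller Alkyl Group on the Cyanoaziridine Urea

This account rests on a few compounds, and the source may have more. Where it says the series, first, only, none or still open, it means among the compounds named here.

Compound 1, `N#CC1CN1C(=O)Nc1ccc(F)cc1`: in a functional assay on MCF7 cells (Homo sapiens) for inhibition (a lower number here means a stronger inhibitor, a higher number a weaker inhibitor), compound 1 gives 2400 nM.
Compound 2, `CC(C)(C)NC(=O)N1CC1C#N`: in this assay compound 2 gives 190000 nM.
Compound 3, `N#CC1CN1C(=O)Nc1ccc(Cl)cc1Cl`: in this assay compound 3 gives 1100 nM.

Among these three numbers compound 2 stands highest, which makes it the weakest inhibitor of the set; both compound 1 and compound 3 give markedly lower numbers, and both gaps lie well beyond the usual scatter. Compound 1 and compound 3 carry an aromatic ring on the urea nitrogen, whereas compound 2 carries a tert-butyl group there.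

Compound 4, `CNC(=O)N1CC1C#N`, has not yet been measured. It differs from compound 2 in one place: methyl in place of tert-butyl on an amide-type nitrogen. Among the measured compounds shown here, no measured pair in this set shows this kind of change, so there is no directly comparable step to lean on. The two aryl ureas differ from compound 2 in more than this one place and give no guide to swapping one alkyl group for another.

The expectation is therefore a small step from compound 2 to compound 4 in this assay, of a 1.3-fold higher number from compound 2 to compound 4 (0.12 log units; within the scatter), with a modest lean toward a higher number. Compound 4 is estimated at 250000 nM, in a range from 60000 nM to 1000000 nM.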

Compound 4, half-maximal inhibitory concentration: 17000 nM
Compound 4: the middle estimate sits 15-fold (1.17 log units) above what was measured; measured number outside the range, below it.
By their numbers in this assay, from the lowest: compound 3; then compound 1; then compound 4; then compound 2.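

In this assay the exchange of tert-butyl for methyl on the amide-type nitrogen gives an 11-fold lower number from compound 2 to compound 4 (1.05 log units; beyond the scatter) and so shows that this position is sensitive to the choice of alkyl group. The earlier compounds shown here could not show this: the two aryl ureas differ from compound 2 in more than one place, and no measured pair isolated a single change at this nitrogen. Here the rest of the molecule stays the same, so the step can be tied to this one exchange, although nothing available explains why the methyl compound gives the lower number.

Going by these compounds, two alkyl groups give only two points, so it remains open whether the number falls steadily as the group shrinks or whether methyl behaves in its own way. Ethyl or isopropyl on the same nitrogen would fill in the range between the two, while hydrogen in place of methyl, or a longer chain such as n-butyl, would test how far any trend extends.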